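A cyclohexyl on silicon, judged from two neighbours

The source may report more compounds than this note shows. Statements on the series, on what has been measured and on what is new or still open speak of the compounds shown alone.

Among the compounds with values here, compound 2 `CCN(C/C=C/C#CC(C)(C)C)Cc1cccc(OC[Si](C)(C)c2ccccc2-c2ccsc2)c1` gives 10000 nM in a functional assay on liver (Sus scrofa) for inhibition of squalene monooxygenase (Homo sapiens), using microsomes (on this read-out higher numbers stand for weaker inhibition and lower numbers for stronger inhibition), the highest of the two numbers measured so far; its nearest neighbour is compound 1 `CCN(C/C=C/C#CC(C)(C)C)Cc1cccc(OC[Si](C)(C)c2ccc(C(=O)C(F)(F)F)cc2)c1`, which gives 5000 nM in this assay, a gap within the scatter. Within the data shown here, the only step between measured compounds, a 2.0-fold higher number from compound 1 to compound 2 (0.30 log units; within the scatter), puts 2-(thiophen-3-yl)phenyl in place of 4-((trifluoromethyl)carbonyl)phenyl on the silicon and leaves the number within the scatter. Compound 3 `CCN(C/C=C/C#CC(C)(C)C)Cc1cccc(OC[Si](C)(C)C2CCCCC2)c1` differs from compound 2 in one place: cyclohexyl in place of 2-(thiophen-3-yl)phenyl on a silicon. Among the measured compounds shown here, no measured step covers a non-aromatic ring entering at this silicon, so the single known step gives only weak guidance. Compound 3 is therefore expected to remain close to compound 2, with an estimated 10000 nM in this assay and a range from 3000 nM to 30000 nM. This corresponds to an expected no change at the digits printed from compound 2 to compound 3 (within the scatter), a step not beyond the scatter.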

Compound 3, half-maximal inhibitory concentration: 20000 nM
Compound 3: middle estimate off by 2.0-fold (0.30 log units), on the low side, and the stated range covers the measured number.
By their numbers in this assay, from the lowest: compounds 1, 2 and 3 (each within the scatter of the next, the first and the last beyond it).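

In this assay, the silicon now has a step with a non-aromatic ring: putting cyclohexyl in place of 2-(thiophen-3-yl)phenyl gives a 2.0-fold higher number from compound 2 to compound 3 (0.30 log units; within the scatter) and so does not separate the two groups, even though both aromatic rings and the sulfur leave. Set against 4-((trifluoromethyl)carbonyl)phenyl, the same cyclohexyl gives a 4.0-fold higher number from compound 1 to compound 3 (0.60 log units; beyond the scatter) and is the first change on this silicon to pass the scatter, though only modestly. Nothing measured here accounts for either step.

The compounds shown leave open whether this reading holds for other saturated groups on the silicon, such as cyclopentyl or tert-butyl. They also leave open whether a group carrying an amine or a carboxylic acid there would shift the number in either direction.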